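A few compounds are considered here, and "the series" means these few. Any claim that something is new, unique, unknown or untested is made for them only; others in the source may bear on it.

Compound 2 `C=C1CC[C@H]2[C@@](C)(CCC(=O)N[C@@]2(C)COC(=O)c2ccc([N+](=O)[O-])cc2)[C@@H]1/C=C/C1=CCOC1=O` is one of a small set of esters that share the same core and differ only in the group attached to a carbonyl carbon. In an assay for inhibition of hexokinase-2 (Homo sapiens), read by coupled enzyme assay, with a stated time of 10 min, in the presence of a further agent that is not named here (a higher number here means a weaker inhibitor, a lower number a stronger inhibitor), compound 2 gives > 50000 nM, which is a limit of the assay rather than a number. Compound 1 `C=C1CC[C@H]2[C@@](C)(CCC(=O)N[C@@]2(C)COC(=O)c2cccnc2)[C@@H]1/C=C/C1=CCOC1=O` carries pyridin-3-yl on that carbonyl carbon, and in this assay compound 1 gives > 50000 nM, again a limit. Compound 3 `C=C1CC[C@H]2[C@@](C)(CCC(=O)N[C@@]2(C)COC(=O)[C@@H]2CCCN2)[C@@H]1/C=C/C1=CCOC1=O` carries pyrrolidin-2-yl there, and in this assay compound 3 gives > 50000 nM, also a limit. Compound 2 therefore stands exactly where every measured compound stands, at the limit of > 50000 nM in this assay, at which 3 of the 3 values shown sit. The steps a step that the two limits leave unreadable from compound 1 to compound 2, a step that the two limits leave unreadable from compound 1 to compound 3 and a step that the two limits leave unreadable from compound 2 to compound 3 cannot be sized for that reason. Compound 4 `C=C1CC[C@H]2[C@@](C)(CCC(=O)N[C@@]2(C)COC(=O)CCCC[C@@H]2CCSS2)[C@@H]1/C=C/C1=CCOC1=O` is the next ester in the set: a group of 9 heavy atoms (7 carbon, 2 sulfur; one five-membered non-aromatic ring with 2 hetero atoms) in place of a group of 9 heavy atoms (6 carbon, 1 nitrogen, 2 oxygen; one six-membered aromatic ring of carbon only), on a carbonyl carbon. Among the compounds with values here, none of the measured steps offers a readable size, so no direction can be drawn from them; what they share is that three quite different groups on that carbonyl carbon all left this assay at its limit. Compound 4 is therefore expected to give 50000 nM, within a range from 15000 nM to 200000 nM, most probably reported as a limit once more. The step of a number no higher from compound 2 to compound 4 (the limit leaves the size open) is thus estimated to be none beyond the scatter.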

Compound 4, half-maximal inhibitory concentration: 9360 nM
The estimate for compound 4 lay 5.3-fold (0.73 log units) above the measured number; measured number below the stated range.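

The group on this carbonyl carbon can change the result: in this assay compound 4, whose group holds a five-membered non-aromatic ring with sulfur atoms, gives 9360 nM, a measured number. The change reads as an at least 5.3-fold lower number from compound 2 to compound 4 (0.72 log units; beyond the scatter), as an at least 5.3-fold lower number from compound 3 to compound 4 (0.72 log units; beyond the scatter) and as an at least 5.3-fold lower number from compound 1 to compound 4 (0.72 log units; beyond the scatter), and each of these gives only the smallest possible size, with the true gap left open. The steps among compound 1, compound 2 and compound 3 still cannot be read, so compound 4 alone stands clear of the limit that the others share: the limit of > 50000 nM in this assay, at which 3 of the 4 values shown sit.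

The compounds shown do not separate the sulfur-containing ring from the carbon chain that carries it, so it remains open whether a cyclopentyl ring on the same chain, or a plain alkyl chain with no ring, would also leave the limit. Within the data shown here, also open is whether the defined stereocentre that enters with this group matters, since no compound here has the opposite arrangement at that centre.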